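Phenethyl ester in place of isopropyl on compound 1

A few compounds are considered here, and "the series" means these few. Any claim that something is new, unique, unknown or untested is made for them only; others in the source may bear on it.

For the measured compounds named here, compound 1, with the structure `CC1=NC(C)=C([N+](=O)[O-])C(c2cccc(Cl)n2)/C1=C(/O)OC(C)C`, was tested in a functional assay (muscle tissue) with Cavia porcellus as the target (on this read-out lower numbers stand for stronger inhibition and higher numbers for weaker inhibition), and gave 16700 nM, the highest number among the three compounds measured so far. Compound 2, `CC1=NC(C)=C([N+](=O)[O-])C(c2ncccc2[N+](=O)[O-])/C1=C(/O)OC(C)C`, gives 3770 nM in this assay, and compound 3, `CC1=NC(C)=C([N+](=O)[O-])C(c2ccccn2)/C1=C(/O)OCCc1ccccc1`, gives 639 nM. Neither of these two differs from compound 1 in only one place, so their numbers show only where compound 1 stands, not what any single change is worth.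

Compound 4, `CC1=NC(C)=C([N+](=O)[O-])C(c2cccc(Cl)n2)/C1=C(/O)OCCc1ccccc1`, differs from compound 1 in one place: phenethyl in place of isopropyl on an oxygen on an unsaturated carbon. Going by the values given here, no measured pair shows this change on its own. Among the compounds with values here, compound 3, the one compound that carries the same phenethyl ester, has the lowest number of the three, but it also differs from compound 1 elsewhere, so the step is uncertain. For compound 4 a step toward a lower number, beyond the scatter, is expected: a 4.8-fold lower number from compound 1 to compound 4 (0.68 log units; beyond the scatter). Compound 4 is therefore estimated at 3500 nM, within a range from 800 nM to 14000 nM.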

Compound 4, half-maximal inhibitory concentration: 1510 nM
Compound 4: the middle estimate sits 2.3-fold (0.37 log units) above what was measured; the range from low to high includes it.
By their numbers in this assay, from the lowest: compound 3; then compound 4; then compound 2; then compound 1.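

Phenethyl in place of isopropyl on an oxygen on an unsaturated carbon gives an 11-fold lower number from compound 1 to compound 4 (1.04 log units; beyond the scatter) in this assay, the first reading of this change on its own, and it is a large step. The chloro group can now be read alone as well: with the phenethyl ester kept, chloro in place of hydrogen on an aromatic carbon gives a 2.4-fold higher number from compound 3 to compound 4 (0.37 log units; beyond the scatter), a modest step. Nothing available explains either step.

With only isopropyl and phenethyl seen on this oxygen, the compounds shown leave open whether the lower number follows the aromatic ring or the chain, which a benzyl, a phenylpropyl or a plain butyl ester would separate. They also leave open whether the ester step holds with the nitro group of compound 2 in place of chloro.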